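Replacing 2-nitrophenyl with thiophen-3-yl on a shared core

This account rests on a few compounds, and the source may have more. Where it says the series, first, only, none or still open, it means among the compounds named here.

Of the compounds shown here, three built on one shared core have been tested in a functional assay on B16-F10 cells (Mus musculus) for antiproliferative activity, read by MTT assay, with a stated time of 48 h; a lower number here means a stronger inhibitor, a higher number a weaker inhibitor. Compound 1 `COc1ccc(C2OC(c3ccc4ccccc4c3)=NN2C(C)=O)cc1` gives 6.86 ug/mL. Compound 2 `CC(=O)N1N=C(c2ccc3ccccc3c2)OC1c1ccc(F)cc1` gives 4.65 ug/mL. Compound 3 `CC(=O)N1N=C(c2ccc3ccccc3c2)OC1c1ccccc1[N+](=O)[O-]` gives 9.01 ug/mL, which places it level with the other two once normal assay scatter is considered.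

Compound 4 `CC(=O)N1N=C(c2ccc3ccccc3c2)OC1c1ccsc1` has not yet been measured. It keeps the core of compound 3 but carries thiophen-3-yl in place of 2-nitrophenyl on a saturated ring carbon.

Among the compounds with values here, three measured steps bear on this change. Two exchange the aromatic group on that same carbon: a 1.3-fold higher number from compound 1 to compound 3 (0.12 log units; within the scatter) and a 1.9-fold higher number from compound 2 to compound 3 (0.29 log units; within the scatter). The third changes a group on the aromatic ring at that position: a 1.5-fold lower number from compound 1 to compound 2 (0.17 log units; within the scatter). All three are small and lie within the scatter. However, none of the measured compounds carries a thiophen-3-yl group, so the data do not show directly what this group does, and the estimate must stay broad.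

No step beyond the scatter is therefore expected in this assay. The expected step is a 1.4-fold lower number from compound 3 to compound 4 (0.14 log units; within the scatter). For compound 4, the estimated value is 6.5 ug/mL, with an expected range from 3 ug/mL to 14 ug/mL.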

Compound 4, half-maximal inhibitory concentration: 8.56 ug/mL
Compound 4: middle estimate off by 1.3-fold (0.12 log units), on the low side, within the range that was stated.
By their numbers in this assay, from the lowest: compounds 2, 1, 4 and 3 (each within the scatter of the next).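

In this assay, within the data shown here, the saturated ring carbon takes a five-membered aromatic ring with a hetero atom much as it takes the substituted phenyl rings of the earlier compounds. Thiophen-3-yl in place of 2-nitrophenyl gives (a 1.1-fold lower number from compound 3 to compound 4 (0.02 log units; within the scatter)), in place of 4-fluorophenyl it gives (a 1.8-fold higher number from compound 2 to compound 4 (0.27 log units; within the scatter)), and in place of 4-methoxyphenyl it gives (a 1.2-fold higher number from compound 1 to compound 4 (0.10 log units; within the scatter)). A phenyl ring is therefore not needed at this carbon for a number of this size, and no group tried there has yet moved the number beyond the scatter, though nothing measured on these compounds explains why the four sit so close together.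

On these data alone, every group on this carbon so far is an aromatic ring, so it remains open whether a non-aromatic group such as cyclohexyl, a plain methyl, or a ring carrying an amine or a carboxylic acid would leave the number in the same place. As far as these compounds go, the acetyl group is also the same in all four compounds, so what a longer chain at that ring nitrogen would do remains unknown.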